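The compounds below may be only part of what the source reports. "The series", "measured", "known", "first", "only" and "open" are said of these compounds alone.

Measured compounds in a functional assay on the whole organism (Pleural cavity) for inhibition, with Rattus norvegicus as the target, at a dose of 25 mg/kg; on this read-out lower numbers stand for less inhibition and higher numbers for more inhibition at the one dose given (going by the name of the read-out):
Compound 1 `CC1(C)C(=O)N(c2ccc(Cl)cc2Cl)c2ncccc21` gives 8%.
Compound 2 `CC1(C)C(=O)N(c2ccc(S(C)(=O)=O)cc2)c2ncccc21` gives 0%.
Compound 3 `CC1(C)C(=O)N(Cc2ccccc2)c2ncccc21` gives 12%.

All three share one core and differ only in the group on the amide nitrogen. Compound 2 sits at the low end of the three numbers; its gap to compound 1 lies within the scatter, and only compound 3 stands beyond it, on the higher side. For the measured compounds named here, no two of the measured compounds differ in one place, so no single step has been measured here, and nothing can be said about what drives the gap between compound 2 and compound 3.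

Compound 4 `CC1(C)C(=O)N(c2ccc(Br)cc2)c2ncccc21` is not yet measured. It is reached from compound 2 by bromo in place of methylsulfonyl on an aromatic carbon. The closest measured analogue in kind is compound 1, which also carries halogen on the aryl ring and gives 8%, within the scatter of compound 2. On that basis the step from compound 2 to compound 4 is expected to be small, a number 8 percentage points higher from compound 2 to compound 4 (within the scatter) in this assay, that is none beyond the scatter. The estimate for compound 4 in this assay is 8%, with a range from 0% to 20%.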

Compound 4, a percentage reported as inhibition, in the whole organism at one dose (the size of the read-out at that dose, not a potency): 55%
Beside the measured number, compound 4's estimate is 47 percentage points below it; measured number above the stated range.
By their numbers in this assay, from the lowest: compounds 2, 1 and 3 (each within the scatter of the next, the first and the last beyond it); then compound 4.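

Working notes: in this assay, the place on the six-membered aromatic ring of carbon only, para to a large group, is the first in this series where a single change can be read, and a number 55 percentage points higher from compound 2 to compound 4 (beyond the scatter) shows that it is far from silent. With the shared core held fixed, replacing methylsulfonyl (4 heavy atoms, 2 hydrogen-bond acceptors) with bromo (1 heavy atom, 0 hydrogen-bond acceptors) is enough on its own to produce a large step in the read-out at this one dose. No measurement to hand bears on what lies behind the size of this step.

With only one step at this place, the compounds shown cannot separate a gain from bromo itself from a loss on removing methylsulfonyl, and a plain hydrogen, fluoro, methoxy, an amine or a carboxylic acid at the same carbon would each help to tell these readings apart. As far as these compounds go, how the read-out at this place changes with dose also stays open, as every number here comes from a single dose.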